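Acylating the amino group of a pyrimidine adenosine ligand

The source may report more compounds than this note shows. Statements on the series, on what has been measured and on what is new or still open speak of the compounds shown alone.

Compound 2, `Nc1ncc(-c2cccc(Cl)c2)c(-c2ccccc2)n1`, was tested in an assay on CHO cells for displacement of a labelled ligand from adenosine receptor A1 (Homo sapiens), read by scintillation counting, with a stated time of 1 h, tested at 1 uM; on this read-out lower numbers stand for less inhibition and higher numbers for more inhibition at the one concentration tested (going by the name of the read-out). In this assay compound 2 gives > 80%, which is a limit of the assay rather than a number. Its two measured neighbours tell the same story. Compound 1, `Cc1cccc(-c2cnc(N)nc2-c2ccccc2)c1`, gives > 80% in this assay, again a limit. Compound 3, `Nc1ncc(-c2ccc(O)c(Cl)c2)c(-c2ccccc2)n1`, gives > 80% in this assay, also a limit. Because of the limit of > 80% in this assay, at which 3 of the 3 values shown sit, the steps a step that the two limits leave unreadable from compound 1 to compound 2 and a step that the two limits leave unreadable from compound 2 to compound 3 cannot be sized. Neither of them touches the amino group in any case.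

Compound 4, `O=C(Nc1ncc(-c2cccc(Cl)c2)c(-c2ccccc2)n1)C1CCCC1`, differs from compound 2 by cyclopentylcarbonyl in place of hydrogen on a nitrogen on an aromatic ring. Going by the values given here, no measured step bears on this change, so the expectation rests only on where compound 2 stands and on the uncertainty that comes with a group nothing here has tested. Compound 4 is expected to give 65%, with a range from 25% to 95%. The step this means, a number at least 15 percentage points lower from compound 2 to compound 4 (beyond the scatter), is expected to be a loss whose size is uncertain and may or may not exceed the scatter.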

Compound 4, a percentage reported as inhibition, at one concentration (the size of the read-out at that concentration, not a potency): 47%
Compound 4: middle estimate off by 18 percentage points, on the high side; the measured number falls inside the stated range.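

Going by these compounds alone, putting cyclopentylcarbonyl on the amino group gives a number at least 33 percentage points lower from compound 2 to compound 4 (beyond the scatter), the first step whose size can be read. The amino nitrogen is therefore a place where a change clearly moves the result in this assay, although compound 4 still gives 47%, a reading at one concentration and not a potency. The earlier steps on the aromatic rings cannot be read, so they cannot be set against this one, because their values stop at a limit: the limit of > 80% in this assay, at which 3 of the 4 values shown sit.

With a single acyl group shown, it remains open whether the loss follows from the cyclopentyl ring or from the carbonyl, a question that an acetyl group, a benzoyl group or a plain methyl on this nitrogen would address. From the compounds shown here alone, it also remains open whether the same change would lower the reading on the core of compound 1 or compound 3.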